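Neopentyl for 1,2-dimethylpropyl on the amide nitrogen

A few compounds are considered here, and "the series" means these few. Any claim that something is new, unique, unknown or untested is made for them only; others in the source may bear on it.

Three amides of the shared core have been run in an ADME assay on HEK293 cells for agonist activity at metabotropic glutamate receptor 5 (Rattus norvegicus), read by fluorescence and calcium flux; on this read-out higher numbers stand for larger maximal responses and lower numbers for smaller maximal responses. Compound 1 `C[C@H](NC(=O)c1ccc(C#Cc2cccc(F)c2)cn1)C(C)(C)C` gives 20%, compound 2 `CC(C)[C@@H](C)NC(=O)c1ccc(C#Cc2cccc(F)c2)cn1` gives 22.5%, and compound 3 `CC(C)[C@H](C)NC(=O)c1ccc(C#Cc2cccc(F)c2)cn1` gives 13.1%, the low end of the three, with both gaps to it inside the scatter. Compounds 2 and 3 form a pair drawn with opposite configuration (the fact that compounds 2 and 3 differ only in the configuration as drawn); the step of a number 9.4 percentage points lower from compound 2 to compound 3 (within the scatter). The chain change a number 2.5 percentage points higher from compound 1 to compound 2 (within the scatter), and a number 6.9 percentage points lower from compound 1 to compound 3 (within the scatter).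

Compound 4 `CC(C)(C)CNC(=O)c1ccc(C#Cc2cccc(F)c2)cn1` differs from compound 3 by neopentyl in place of 1,2-dimethylpropyl on an amide-type nitrogen. The closest guide is the chain swap from compound 1 to compound 2, which stayed within the scatter, so no step beyond the scatter is expected: a number 4.9 percentage points higher from compound 3 to compound 4 (within the scatter). Compound 4 is therefore estimated at 18%, between 8% and 30% in this assay.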

Compound 4, largest response reached (reported as efficacy), in percent of the reference or control that the assay uses: 9.5%
For compound 4 the middle estimate is 8.5 percentage points above the measured one, within the range that was stated.
By their numbers in this assay, from the lowest: compounds 4, 3, 1 and 2 (each within the scatter of the next, the first and the last beyond it).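

Neopentyl on the amide-type nitrogen gives the first steps beyond the scatter in this series: a number 13 percentage points lower from compound 2 to compound 4 (beyond the scatter), and a number 10.5 percentage points lower from compound 1 to compound 4 (beyond the scatter). Read from the other drawn configuration, the same swap stays inside the scatter, a number 3.6 percentage points lower from compound 3 to compound 4 (within the scatter), so the reading of this change depends on which of the two configured amides serves as reference: the fact that compounds 2 and 3 differ only in the configuration as drawn

Open, on these data alone, is whether a longer chain or a cyclohexyl group on the amide-type nitrogen would give a maximal response outside the range of these four amides.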